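The source may hold more compounds than are shown below. What is called first, only, known or untested is meant among the compounds shown, and "the series" means these compounds.

Measured so far in a functional assay on A549 cells (Homo sapiens) for cytotoxicity, read by colorimetric assay and MTT assay, with a stated time of 3 days, tested at 1 uM; on this read-out lower numbers stand for a stronger effect and higher numbers for a weaker effect at the one concentration tested:
compound 1 `COc1ccc(-c2nc(-c3ccccc3)c(-c3ccc4c(c3)NC(=O)CO4)[nH]2)cc1`: 101%
compound 2 `O=C1COc2ccc(-c3nn(-c4ccc(Br)cc4)cc3-c3ccccc3)cc2N1`: 81.5%
compound 3 `O=C1COc2ccc(-c3nn(-c4cc(Cl)cc(Cl)c4)cc3-c3ccccc3)cc2N1`: 93.1%

Compound 1 stands at the upper end of the three numbers shown, which here means the weakest effect. Its gap to compound 3 is within the scatter; its gap to compound 2 is beyond it. Among the compounds with values here, the one step computed between measured compounds, a number 11.6 percentage points higher from compound 2 to compound 3 (beyond the scatter), sits on the other core of the series and concerns the aryl group on an aromatic nitrogen; it does not touch the place that changes here and bears on the present step only in showing that aryl substituent changes moved the read-out by a modest amount at most.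

Compound 4 `O=C1COc2ccc(-c3[nH]c(-c4ccccc4)nc3-c3ccccc3)cc2N1` differs from compound 1 by hydrogen in place of methoxy on an aromatic carbon. Within the data shown here, no measured pair shows this change, so there is no direct precedent. With compound 1 already at 101% and all three numbers lying in a band of weak effect, removal of the methoxy is expected to leave the read-out where it is.

Compound 4 is therefore estimated at 98%, with a range from 85% to 110%. For compound 4 the expected step is a number 3 percentage points lower from compound 1 to compound 4 (within the scatter), not beyond the scatter.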

Compound 4, a percentage reported as activity, at one concentration (the size of the read-out at that concentration, not a potency): 95.6%
Compound 4: the middle estimate sits 2.4 percentage points above what was measured; the measured number falls inside the stated range.
By their numbers in this assay, from the lowest: compound 2; then compounds 3, 4 and 1 (each within the scatter of the next).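

In this assay, within the data shown here, the change from 4-methoxyphenyl to phenyl gives a number 5.4 percentage points lower from compound 1 to compound 4 (within the scatter), the first reading of any change at this place, on an aromatic carbon of a six-membered aromatic ring of carbon only, para to a large group. Among these compounds, the methoxy can thus leave this place without a change in the read-out that stands clear of the scatter: compound 1 gives 101% and compound 4 gives 95.6%, so at the one concentration tested neither number separates the pair, and the methoxy shows no role of its own in this assay. No supporting data are available to explain this result, so it stands as an observation only.

The compounds shown leave open whether any other group at this place, such as an amine or a carboxylic acid, would bring the read-out beyond the scatter from compound 4. Also open, going by these compounds, is whether the change from 4-methoxyphenyl to phenyl would read the same way on the core of compound 2, where the aryl group on the aromatic nitrogen has already moved the number by a number 11.6 percentage points higher from compound 2 to compound 3 (beyond the scatter).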